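Swapping the aryl group on the amide of compound 2

The source may report more compounds than this note shows. Statements on the series, on what has been measured and on what is new or still open speak of the compounds shown alone.

- compound 1 `O=C(CSc1nncnc1-c1cccc2ccccc12)Nc1ccccc1[N+](=O)[O-]` gives 142000 nM
- compound 2 `CC(=O)c1ccc(NC(=O)CSc2nncnc2-c2cccc3ccccc23)c(Br)c1` gives 133000 nM

In an ADME assay on MT4 cells (Homo sapiens) for cytotoxicity, read by MTT assay (on this read-out higher numbers stand for lower toxicity in this test and lower numbers for higher toxicity in this test), compound 2 gives 133000 nM and compound 1 gives 142000 nM, and these two numbers lie within the usual scatter of each other. Compound 3 `O=C(CSc1nncnc1-c1cccc2ccccc12)Nc1ccccc1Cl` has not been measured yet. It carries 2-chlorophenyl in place of 4-acetyl-2-bromophenyl on an amide-type nitrogen.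

Going by the values given here, only one measured step bears on this change, and it alters the group at the same place. That step is a 1.1-fold lower number from compound 1 to compound 2 (0.03 log units; within the scatter), so swapping this group has so far produced no shift beyond the scatter. One step is thin evidence, but it gives no reason to expect a real shift in this assay, in either direction. The expected change is a 1.0-fold lower number from compound 2 to compound 3 (0.01 log units; within the scatter). For compound 3 the estimated value is 130000 nM, with an expected range from 60000 nM to 260000 nM.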

Compound 3, half-maximal cytotoxic concentration: 63000 nM
Compound 3: middle estimate off by 2.1-fold (0.31 log units), on the high side, within the range that was stated.
By their numbers in this assay, from the lowest: compound 3; then compounds 2 and 1 (each within the scatter of the next).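

In this assay this place on the amide-type nitrogen no longer looks indifferent: the aryl swap gives a 2.1-fold lower number from compound 2 to compound 3 (0.32 log units; beyond the scatter), whereas the earlier swap stayed within the scatter. Chloro in place of nitro on an aromatic carbon points the same way, with a 2.3-fold lower number from compound 1 to compound 3 (0.35 log units; beyond the scatter), so compound 3 stands apart from both earlier compounds, modestly, on the side of higher toxicity in this test. No measurement at hand explains this shift.

The three compounds leave open whether the shift is particular to the chlorine of 2-chlorophenyl or would also appear with a plain phenyl, a fluorine or a methoxy group at this place. They also leave open how an amine or a carboxylic acid on this aryl ring would read in this assay.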